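The source may report more compounds than this note shows. Statements on the series, on what has been measured and on what is new or still open speak of the compounds shown alone.

Measured compounds:
- compound 1 `CC1(C)CC(=O)c2cc(C#N)c(NC3CCCC3)nc2C1` — in an in vitro functional assay on cells for antagonist activity at metabotropic glutamate receptor 1 (Rattus norvegicus), read by inositol phosphate accumulation (a higher number here means a weaker inhibitor, a lower number a stronger inhibitor), compound 1 gives 78 nM
- compound 2 `CC1(C)CC(=O)c2cc(C#N)c(NC3CCCCC3)nc2C1` — compound 2 gives 4000 nM
- compound 3 `CCCNc1nc2c(cc1C#N)C(=O)CC(C)(C)C2` — compound 3 gives 2300 nM

Compound 3 stands second highest of the three numbers. Its nearest neighbour is compound 2, with a 1.7-fold lower number from compound 2 to compound 3 (0.24 log units; within the scatter), a gap within the scatter, so the two are not told apart. The furthest is compound 1, with a 29-fold higher number from compound 1 to compound 3 (1.47 log units; beyond the scatter), a large step beyond the scatter.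

Compound 4 `CCCCNc1nc2c(cc1C#N)C(=O)CC(C)(C)C2` is not yet measured in this assay. The change from compound 3 is methyl in place of hydrogen on a saturated chain carbon, three bonds along the chain from a nitrogen on an aromatic ring, that is, butyl in place of propyl on the nitrogen on the aromatic ring.

Going by the values given here, no measured step adds one carbon to an open chain here. The nearest case is the ring enlarged by one carbon, a 51-fold higher number from compound 1 to compound 2 (1.71 log units; beyond the scatter), which was large; and the chain substituent itself sits well off compound 1, a 29-fold higher number from compound 1 to compound 3 (1.47 log units; beyond the scatter). Both only show that changes at this nitrogen can move the number a long way; neither tells the direction for a longer chain. With compound 3 already near the weak end of the series, a step of modest size is expected, a 1.3-fold higher number from compound 3 to compound 4 (0.12 log units; within the scatter), most likely weaker or unchanged within the scatter. Compound 4 is estimated at 3000 nM, with a range from 900 nM to 10000 nM.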

Compound 4, half-maximal inhibitory concentration: 1700 nM
Estimate against measurement, compound 4: 1.8-fold (0.25 log units) above; the measured number falls inside the stated range.
By their numbers in this assay, from the lowest: compound 1; then compounds 4, 3 and 2 (each within the scatter of the next, the first and the last beyond it).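

In this assay, butyl in place of propyl on the nitrogen gives a 1.4-fold lower number from compound 3 to compound 4 (0.13 log units; within the scatter), so the two chains are not told apart and this added methyl has no readable effect. Butyl remains far from cyclopentyl, with a 22-fold higher number from compound 1 to compound 4 (1.34 log units; beyond the scatter), whereas a 2.4-fold lower number from compound 2 to compound 4 (0.37 log units; beyond the scatter) is only a modest step from cyclohexyl. Compound 1 alone stands apart among the four, yet no simple ring-over-chain pattern follows, since compound 2 also carries a ring and goes against it.

From the compounds shown here alone, whether a longer chain such as hexyl, a branched chain such as isopropyl or a smaller ring such as cyclobutyl would come closer to compound 1 stays open. No supporting data are available to explain the position of cyclopentyl among the groups on this nitrogen.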